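Benzyloxy to butoxy on the shared core

A few compounds are considered here, and "the series" means these few. Any claim that something is new, unique, unknown or untested is made for them only; others in the source may bear on it.

Measured in an ADME assay on KB cells (Homo sapiens) for cytotoxicity; a higher number here means that more compound is needed for the effect, a lower number that less compound is needed:
- compound 1 `COC(=O)N1[C@@H]2C=C[C@@](OC)(C(=O)c3c2cc(OC)c(OC)c3OCc2ccccc2)N1C(=O)OC`: > 300 ug/mL
- compound 2 `CCOc1c(OC)c(OC)cc2c1C(=O)[C@]1(OC)C=C[C@H]2N(C(=O)OCC(C)C)N1C(=O)OCC(C)C`: > 300 ug/mL
- compound 3 `CCCCOc1c(OC)c(OC)cc2c1C(=O)[C@]1(OC)C=C[C@H]2N(C(=O)OCC)N1C(=O)OCC`: 76 ug/mL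

Compound 1 gives only a limit and no number, and it stands with compound 2 at the limit of > 300 ug/mL in this assay, at which 2 of the 3 values shown sit. Compound 4 `CCCCOc1c(OC)c(OC)cc2c1C(=O)[C@]1(OC)C=C[C@H]2N(C(=O)OC)N1C(=O)OC` keeps the core of compound 1 and carries propyl in place of phenyl on a saturated chain carbon bound to an oxygen on an aromatic ring, which reads as benzyloxy to butoxy: propyl in place of phenyl on a saturated chain carbon bound to an oxygen on an aromatic ring. Within the data shown here, no measured pair isolates this change. The expectation rests on compound 3, which also carries butoxy and gives 76 ug/mL. A downward step beyond the scatter is expected in this assay, estimated as an at least 2.7-fold lower number from compound 1 to compound 4 (0.43 log units; beyond the scatter). For compound 4 the expected value is 110 ug/mL, with an estimated range from 40 ug/mL to 300 ug/mL.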

Compound 4, concentration for half-maximal effect: > 300 ug/mL
Compound 4: only a limit was reported; the forecaster's own chance of this, stated with the estimate: 25%; middle value at least 2.7-fold (0.43 log units) away from the limit.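

Compound 1 and compound 4 both end at a limit, so no step can be read between them: the limit of > 300 ug/mL in this assay, at which 3 of the 4 values shown sit.
On these data alone, whether benzyloxy to butoxy shifts the number on the shared core stays open.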